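Methoxy placement on the styryl ring of aryl vinyl sulfones

This account rests on a few compounds, and the source may have more. Where it says the series, first, only, none or still open, it means among the compounds named here.

The series holds four compounds with a shared core. Compound 1 is `COc1ccc(/C=C/S(=O)(=O)Cc2ccc(OC)cc2)cc1`, compound 2 is `COc1ccc(CS(=O)(=O)/C=C/c2ccccc2OC)cc1`, compound 3 is `COc1ccc(CS(=O)(=O)/C=C/c2ccc(OC)c(OC)c2)cc1`, and compound 4, `COc1ccc(CS(=O)(=O)/C=C/c2c(OC)cccc2OC)cc1`, has not yet been measured. The difference between the core of compound 1 and the core of compound 2 is not broken down here.

For the measured compounds named here, in a functional assay on H157 cells (Homo sapiens) for antiproliferative activity, read by trypan blue exclusion (on this read-out lower numbers stand for stronger inhibition and higher numbers for weaker inhibition), compound 2 gives 5000 nM, the only number in the set. For compound 1 this assay reports only a limit, > 20000 nM. For compound 3 it likewise reports only a limit, > 20000 nM. The change methoxy in place of hydrogen on an aromatic carbon therefore corresponds to a step that the two limits leave unreadable from compound 1 to compound 3, left unreadable due to the limit of > 20000 nM in this assay, at which 2 of the 3 values shown sit.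

Compound 4 arises from compound 2 by methoxy in place of hydrogen on an aromatic carbon. Going by the values given here, this is the same kind of change as the one from compound 1 to compound 3, but not the same: in compound 3 the entering group sits ortho to a methoxy group and meta to a large group, whereas in compound 4 it sits ortho to a large group and meta to a methoxy group.

For compound 4 a step of a 1.8-fold higher number from compound 2 to compound 4 (0.26 log units; within the scatter) in this assay is expected. That rests on compound 2 at 5000 nM as the only readable anchor, while the earlier step that the two limits leave unreadable from compound 1 to compound 3 gives no size to carry over. Compound 4 is estimated at 9000 nM, expected between 2500 nM and 20000 nM.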

Compound 4, half-maximal inhibitory concentration: 700 nM
Compound 4: the middle estimate sits 13-fold (1.11 log units) above what was measured; the whole stated range lies above it.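

In this assay, methoxy in place of hydrogen on an aromatic carbon, ortho to a large group and meta to a methoxy group, gives a 7.1-fold lower number from compound 2 to compound 4 (0.85 log units; beyond the scatter), a step beyond the scatter and the one readable effect of this change in the series. On the core of compound 1, the same kind of change sits at a different place, and compound 1 and compound 3 are both reported only as limits, so their step cannot be read and shows neither that the gain carries over to another core nor that it fails to. The evidence for this change therefore amounts to a single step on one core, and the comparison across cores stops at the assay limit: the limit of > 20000 nM in this assay, at which 2 of the 4 values shown sit.

As far as these compounds go, it remains open whether the lower number in compound 4 depends on methoxy itself or would also appear with a hydroxyl, an ethoxy group or an amine at the same place. From the compounds shown here alone, it is also open whether methoxy at that place on the core of compound 1 would give a value that can be read as a number, which is what a real comparison between the two cores would need.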